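Cyclopropyl to 4-hydroxyphenyl on the ketone of the shared core

The source may hold more compounds than are shown below. What is called first, only, known or untested is meant among the compounds shown, and "the series" means these compounds.

Measured compounds in a functional assay on MCF7 cells (Homo sapiens) for cytotoxicity, read by MTT assay, with a stated time of 48 h; on this read-out higher numbers stand for weaker inhibition and lower numbers for stronger inhibition:
Compound 1, `COc1cc(-c2nnc3n2NC(c2ccco2)C(C(=O)c2ccco2)S3)cc(OC)c1OC`, > 100000 nM, a limit of the assay.
Compound 2, `COc1cc(-c2nnc3n2NC(c2ccco2)C(C(=O)C2CC2)S3)cc(OC)c1OC`, > 100000 nM, a limit of the assay.
Compound 3, `COc1cccc(C(=O)C2Sc3nnc(-c4cc(OC)c(OC)c(OC)c4)n3NC2c2ccco2)c1`, > 100000 nM, a limit of the assay.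

In this assay compound 2 stands only at a limit, > 100000 nM, and no number is known for it. The same holds for the two other compounds, since (the limit of > 100000 nM in this assay, at which 3 of the 3 values shown sit). Compound 4, `COc1cc(-c2nnc3n2NC(c2ccco2)C(C(=O)c2ccc(O)cc2)S3)cc(OC)c1OC`, differs from compound 2 in one place: 4-hydroxyphenyl in place of cyclopropyl on a carbonyl carbon. The measured steps that change the same carbonyl substituent, a step that the two limits leave unreadable from compound 1 to compound 2, a step that the two limits leave unreadable from compound 1 to compound 3 and a step that the two limits leave unreadable from compound 2 to compound 3, all run between limits and cannot be read in size or direction. They give no sign that a change at this carbonyl carbon moves the read-out away from the limit, so for compound 4 no readable step is expected; the expected step of a number no higher from compound 2 to compound 4 (the limit leaves the size open) is taken as none beyond the scatter. Compound 4 is therefore estimated at 100000 nM, within 30000 nM to 300000 nM, most likely reported again as a limit.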

Compound 4, half-maximal inhibitory concentration: 88900 nM
Estimate against measurement, compound 4: 1.1-fold (0.05 log units) above; the measured number falls inside the stated range.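

In this assay, compound 4 is the only one of the four shown with a number rather than a limit, 88900 nM, so this carbonyl carbon can carry a substituent that gives a measurable value, whereas the steps among compound 1, compound 2 and compound 3 cannot be read. The change to 4-hydroxyphenyl gives an at least 1.1-fold lower number from compound 2 to compound 4 (0.05 log units; that floor lies within the scatter), an at least 1.1-fold lower number from compound 3 to compound 4 (0.05 log units; that floor lies within the scatter) and an at least 1.1-fold lower number from compound 1 to compound 4 (0.05 log units; that floor lies within the scatter), so compound 4 is not shown to differ from any of the three. The true size of these steps stays open because the other compounds give no number: the limit of > 100000 nM in this assay, at which 3 of the 4 values shown sit.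

The compounds shown leave open what a plain phenyl, a 4-methoxyphenyl or a 4-aminophenyl group would give on this carbonyl carbon. They also leave open whether any group there can move the value clearly beyond the scatter.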